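Triple methoxy on the benzyl arm of compound 2

This account rests on a few compounds, and the source may have more. Where it says the series, first, only, none or still open, it means among the compounds named here.

Measured so far:
compound 2, `COc1ccc(CNc2nc3cc(N)cc(N)c3nc2-c2ccccc2)cc1OC`: 13500 nM
compound 3, `CCOC(=O)[C@H](CCC(=O)O)NC(=O)c1ccc(Sc2nc3cc(N)cc(N)c3nc2-c2ccccc2)cc1`: 6310 nM
compound 1, `CCOC(=O)[C@H](CCC(=O)O)NC(=O)c1ccc(CNc2nc3cc(N)cc(N)c3nc2-c2ccccc2)cc1`: a limit, < 100000 nM

Three compounds share the core and were tested in a functional assay on BT-549 cells (Homo sapiens) for inhibition, read by sulforhodamine B assay, with a stated time of 48 h; on this read-out lower numbers stand for stronger inhibition of growth and higher numbers for weaker inhibition of growth. Compound 2 gives 13500 nM. Compound 3 gives 6310 nM. For compound 1 the outcome is only a limit of the assay, < 100000 nM, and not a number; (the limit of < 100000 nM in this assay, at which 1 of the 3 values shown sits). Among the two numbers, compound 2 stands as the higher one, and its nearest neighbour, compound 3, sits beyond the scatter below it.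

The unmeasured compound 4, `COc1cc(CNc2nc3cc(N)cc(N)c3nc2-c2ccccc2)cc(OC)c1OC`, differs from compound 2 in one place: methoxy in place of hydrogen on an aromatic carbon. Within the data shown here, no comparable single step between measured compounds has been recorded, so there is nothing to lean on for the size of this change. The author's expectation is that it stays small, either direction, within the scatter of this assay, and so the step of a 1.2-fold lower number from compound 2 to compound 4 (0.09 log units; within the scatter) in this assay is estimated to be modest at most. On that basis compound 4 is expected to give about 11000 nM, with a range from 3500 nM to 35000 nM.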

Compound 4, concentration for 50% growth inhibition: 3800 nM
Compound 4: the middle estimate sits 2.9-fold (0.46 log units) above what was measured; low and high end bracket the measured number.
By their numbers in this assay, from the lowest: compounds 4 and 3 (each within the scatter of the next); then compound 2.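

In this assay, among these compounds, the added methoxy is the first single change whose size can be read, and it gives a 3.6-fold lower number from compound 2 to compound 4 (0.55 log units; beyond the scatter) with the new group ortho to a methoxy group, meta to a methoxy group and meta to a large group. This aromatic carbon of the benzyl arm is therefore not a silent position: replacing its hydrogen with a methoxy, which adds no ring and no net charge, moves the number beyond the scatter, towards stronger inhibition of growth. Nothing given here bears on why this one group has that effect.

The compounds shown hold only this one replacement at this carbon, so it remains open whether a hydroxy group, a fluorine atom, an amine or an ethoxy group there would move the number the same way or as far. From the compounds shown here alone, it also remains open whether the step depends on the two methoxy groups already on the ring, and whether it would carry over to the other arms of the shared core.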